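Adding fluorine to the pendant aryl ring: compound 2 to compound 3

A few compounds are considered here, and "the series" means these few. Any claim that something is new, unique, unknown or untested is made for them only; others in the source may bear on it.

For the measured compounds named here, compound 2 `COc1cc2c(Oc3ccc(NC(=O)NN4C(=O)CSC4c4ccccc4)cc3)ccnc2cc1OC1CCN(C(=O)NC(C)C)CC1` gives 1260 nM in a functional assay on HT-29 cells (Homo sapiens) for inhibition, read by MTT assay (on this read-out higher numbers stand for weaker inhibition and lower numbers for stronger inhibition), the highest of the two numbers measured so far; its nearest neighbour is compound 1 `COc1cc2c(Oc3ccc(NC(=O)NN4C(=O)CSC4c4ccc(F)cc4)cc3)ccnc2cc1OC1CCN(C(=O)NC(C)C)CC1`, which gives 860 nM in this assay. Going by the values given here, the only measured step, a 1.5-fold higher number from compound 1 to compound 2 (0.17 log units; within the scatter), lies within the scatter. Compound 3 `COc1cc2c(Oc3ccc(NC(=O)NN4C(=O)CSC4c4ccc(F)c(F)c4)cc3)ccnc2cc1OC1CCN(C(=O)NC(C)C)CC1` has not been measured; it differs from compound 2 by 3,4-difluorophenyl in place of phenyl on a saturated ring carbon. The step from compound 1 to compound 2, which concerns fluorine on the same aromatic ring, is the only one that bears on this change, and it was small. The expectation for compound 3 in this assay is therefore a step of a 1.6-fold lower number from compound 2 to compound 3 (0.20 log units; within the scatter) toward a somewhat lower number, not clearly beyond the scatter. Compound 3 is estimated at 800 nM, with a range from 350 nM to 1800 nM.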

Compound 3, half-maximal inhibitory concentration: 1060 nM
The estimate for compound 3 lay 1.3-fold (0.12 log units) below the measured number, within the range that was stated.
By their numbers in this assay, from the lowest: compounds 1, 3 and 2 (each within the scatter of the next).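

In this assay, putting 3,4-difluorophenyl in place of phenyl on the saturated ring carbon gives a 1.2-fold lower number from compound 2 to compound 3 (0.08 log units; within the scatter). Placing a further fluoro in place of hydrogen on the aromatic ring gives a 1.2-fold higher number from compound 1 to compound 3 (0.09 log units; within the scatter). Neither fluoro change separates compound 3 from its neighbours, so across compound 1, compound 2 and compound 3 this position shows no response to fluoro beyond the scatter. No accompanying measurement offers an explanation for these numbers.

The compounds shown leave open whether this position responds to any substituent other than fluoro, such as a methoxy group, a dimethylamino group or a carboxylic acid on the phenyl ring. As far as these compounds go, it also remains open how a pyridine ring or a cyclohexyl group in place of phenyl would read in this assay.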